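A halogen rearrangement from compound 3 to compound 4

The compounds below may be only part of what the source reports. "The series", "measured", "known", "first", "only" and "open" are said of these compounds alone.

Measured compounds:
compound 1 `O=C(Nc1cccnc1)c1ccccc1OCc1ccccc1Cl` — 1100 nM
compound 2 `Cc1ccccc1COc1ccccc1C(=O)Nc1cccnc1` — 1500 nM
compound 3 `O=C(Nc1cccnc1)c1ccccc1OCc1cc(F)ccc1Cl` — 740 nM

In an assay on lysate for inhibition of phosphatidylcholine:ceramide cholinephosphotransferase 2 (Homo sapiens), read by HPLC, with stated times of 30 min and 2 h (on this read-out higher numbers stand for weaker inhibition and lower numbers for stronger inhibition), compound 3 gives 740 nM, the lowest of the three numbers, though its gap to compound 1 lies within the scatter; only its gap to compound 2 is beyond it. For the measured compounds named here, the steps among the measured compounds are all small: a 1.4-fold higher number from compound 1 to compound 2 (0.13 log units; within the scatter), a 1.5-fold lower number from compound 1 to compound 3 (0.17 log units; within the scatter), and the one step that clears the scatter, a 2.0-fold lower number from compound 2 to compound 3 (0.31 log units; beyond the scatter).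

Compound 4 `O=C(Nc1cccnc1)c1ccccc1OCc1cccc(Cl)c1F` differs from compound 3 by 3-chloro-2-fluorophenyl in place of 2-chloro-5-fluorophenyl on a saturated chain carbon bound to an oxygen on an aromatic ring. The same atoms are present; only their arrangement around the ring changes. Going by the values given here, none of the measured steps moves a halogen from one ring position to another, so none bears on this change directly. What they do show is that small exchanges on this ring, chloro for methyl or fluoro for hydrogen, stayed within the scatter, and even the largest step was only modest. Among the compounds with values here, compound 4 is therefore expected to land close to compound 3, with no step in this assay beyond the scatter: a 1.4-fold higher number from compound 3 to compound 4 (0.13 log units; within the scatter). The estimate for compound 4 is 1000 nM, with a range from 400 nM to 2500 nM.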

Compound 4, half-maximal inhibitory concentration: 3100 nM
The estimate for compound 4 lay 3.1-fold (0.49 log units) below the measured number; the whole stated range lies below it.
By their numbers in this assay, from the lowest: compounds 3, 1 and 2 (each within the scatter of the next, the first and the last beyond it); then compound 4.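

In this assay, for the compounds shown here, the arrangement of the two halogens on the phenyl ring held by the saturated chain carbon matters even though the atoms stay the same: 3-chloro-2-fluorophenyl in place of 2-chloro-5-fluorophenyl gives a 4.2-fold higher number from compound 3 to compound 4 (0.62 log units; beyond the scatter), a larger step than any among the earlier compounds, whose exchanges at this place were either within the scatter or only just beyond it. The new arrangement also compares poorly with the simpler rings, with a 2.8-fold higher number from compound 1 to compound 4 (0.45 log units; beyond the scatter) and a 2.1-fold higher number from compound 2 to compound 4 (0.32 log units; beyond the scatter), so that adding a fluoro to a chloro-bearing ring, which stayed within the scatter in compound 3, does not carry over to this arrangement, and compound 4 has the highest number of the four. Going by these compounds alone, nothing available explains why this rearrangement shifts the number so far.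

Which of the two halogens carries the step stays open, as the compounds shown include no ring with 3-chlorophenyl or 2-fluorophenyl alone at this place. How a methoxy group or a nitrile would fare on this ring is likewise unknown.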